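The compounds below may be only part of what the source reports. "The series", "measured", "known", "first", "only" and "open" are said of these compounds alone.

Measured so far in a functional assay on K562 cells (Homo sapiens), read by MTT assay, with a stated time of 72 h; on this read-out lower numbers stand for stronger inhibition and higher numbers for weaker inhibition:
Compound 1 `O=c1[nH]cnc2c1c(-c1ccsc1)cn2[C@@H]1O[C@H](CO)[C@@H](O)[C@H]1O` gives > 20000 nM, which is a limit of the assay and not a number.
Compound 2 `O=c1[nH]cnc2c1c(-c1ccccc1)cn2[C@@H]1O[C@H](CO)[C@@H](O)[C@H]1O` gives > 20000 nM, again only a limit.
Compound 3 `Nc1nc2c(c(-c3ccccc3)cn2[C@@H]2O[C@H](CO)[C@@H](O)[C@H]2O)c(=O)[nH]1` gives > 20000 nM, likewise a limit.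

Every shown value sits at the same limit (the limit of > 20000 nM in this assay, at which 3 of the 3 values shown sit), so no step between them can be sized. Compound 1 and compound 2 differ by thiophen-3-yl in place of phenyl on an aromatic carbon, and the step that the two limits leave unreadable from compound 2 to compound 1 stays unreadable. The cores of compound 3 and compound 2 differ by amino in place of hydrogen on an aromatic carbon; the step that the two limits leave unreadable from compound 2 to compound 3 is equally unreadable. Compound 4 `Nc1nc2c(c(-c3ccsc3)cn2[C@@H]2O[C@H](CO)[C@@H](O)[C@H]2O)c(=O)[nH]1` is not yet measured and differs from compound 3 by thiophen-3-yl in place of phenyl on an aromatic carbon, the same change that leads from compound 2 to compound 1, at a place described in the same words. With all three neighbours at the limit, compound 4 is expected to remain there as well, with an estimated value of 40000 nM, between 15000 nM and 150000 nM. The expected step that the limit leaves unreadable from compound 3 to compound 4 is therefore a guess rather than a reading.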

Compound 4, half-maximal inhibitory concentration: > 20000 nM
Compound 4: only a limit was reported (the forecaster's own chance of this, stated with the estimate: 85%); the middle value lies beyond the limit too.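

Compound 4 gives only a limit, so the steps to it from compound 3 and from compound 1 cannot be read: the limit of > 20000 nM in this assay, at which 4 of the 4 values shown sit.

The compounds shown leave open whether thiophen-3-yl in place of phenyl, or amino in place of hydrogen, changes the result in this assay at all.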